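This account rests on a few compounds, and the source may have more. Where it says the series, first, only, none or still open, it means among the compounds named here.

Measured in a functional assay on MDA-MB-231 cells (Homo sapiens) for cytotoxicity, read by MTT assay, with a stated time of 48 h; on this read-out higher numbers stand for weaker inhibition and lower numbers for stronger inhibition:
- Compound 1 `O=c1ccoc2cc(OCc3cn(Cc4ccccc4)nn3)ccc12`: > 100000 nM (a limit)
- Compound 2 `O=c1ccoc2cc(OCc3cn(Cc4ccc(F)cc4)nn3)ccc12`: > 100000 nM (a limit)
- Compound 3 `O=c1ccoc2cc(OCc3cn(Cc4cccc(Cl)c4)nn3)ccc12`: > 100000 nM (a limit)

Compound 3 gives > 100000 nM, which is a limit and not a number. Among the compounds with values here, the whole series so far comes down to the limit of > 100000 nM in this assay, at which 3 of the 3 values shown sit. Within the data shown here, no measured compound therefore offers a true number to compare with.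

The next compound, compound 4 `O=c1ccoc2cc(OCc3cn(Cc4ccccc4Cl)nn3)ccc12`, keeps the same atoms but joins them differently: 2-chlorophenyl in place of 3-chlorophenyl on a saturated chain carbon bound to an aromatic nitrogen. In words, 2-chlorophenyl takes the place of 3-chlorophenyl on a saturated chain carbon bound to an aromatic nitrogen, so that 3-chlorobenzyl becomes 2-chlorobenzyl.

Among the measured compounds shown here, three measured steps bear on this change: a step that the two limits leave unreadable from compound 1 to compound 2, a step that the two limits leave unreadable from compound 1 to compound 3 and a step that the two limits leave unreadable from compound 2 to compound 3. Each has a limit at both ends and gives no size. Changes to this aromatic ring have so far never produced a readable value in this assay, and this holds for all three compounds measured.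

The expected outcome is therefore a step that the limit leaves unreadable from compound 3 to compound 4, with no direction that the data can support. Another limit is the most likely report. For compound 4 the estimated value is 120000 nM, with an expected range from 50000 nM to 300000 nM.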

Compound 4, half-maximal inhibitory concentration: 15100 nM
Beside the measured number, compound 4's estimate is 7.9-fold (0.90 log units) above it; the measured number lies below the stated range.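

Exchanging 3-chlorobenzyl for 2-chlorobenzyl, with the same atoms joined differently, gives an at least 6.6-fold lower number from compound 3 to compound 4 (0.82 log units; beyond the scatter), which shows that in this assay the place of the chloro group on this aromatic ring can decide whether a readable value appears at all. The same gain shows against the other two relatives: 2-chlorophenyl in place of 4-fluorophenyl gives an at least 6.6-fold lower number from compound 2 to compound 4 (0.82 log units; beyond the scatter), and chloro in place of hydrogen on an aromatic carbon gives an at least 6.6-fold lower number from compound 1 to compound 4 (0.82 log units; beyond the scatter). Each of these steps gives only a minimum size, and the steps among compound 1, compound 2 and compound 3 cannot be read, so compound 4 alone stands apart from a shared ceiling: the limit of > 100000 nM in this assay, at which 3 of the 4 values shown sit.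

As far as these compounds go, whether the chloro group itself matters, or whether a bromo, methyl or methoxy group in its stead would also give a readable value, stays open. Also open, from the compounds shown here alone, is how the value would respond to an amine or a carboxylic acid on this ring, or to a longer chain in place of the benzyl link.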